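The source may report more compounds than this note shows. Statements on the series, on what has been measured and on what is new or still open speak of the compounds shown alone.

Measured in a functional assay on A2780 cells (Homo sapiens) for antiproliferative activity, read by MTT assay, with a stated time of 48 h; a higher number here means a weaker inhibitor, a lower number a stronger inhibitor:
- compound 1 `COc1ccc(-c2cc3c(cn2)[nH]c(=O)n3-c2cc(OC)c(OC)c(OC)c2)cc1F`: 730 nM
- compound 2 `COc1ccc(-c2cc3c(cn2)[nH]c(=O)n3-c2cc(OC)c(OC)c(OC)c2)cc1O`: 240 nM
- compound 3 `COc1ccc(-c2cc3c(cn2)n(C)c(=O)n3-c2cc(OC)c(OC)c(OC)c2)cc1O`: 1720 nM

Of these three, compound 3 has the highest number, 1720 nM, which makes it the weakest inhibitor of the set. Compound 4 `CCn1c(=O)n(-c2cc(OC)c(OC)c(OC)c2)c2cc(-c3ccc(OC)c(O)c3)ncc21` has not been measured yet. It differs from compound 3 by methyl in place of hydrogen on a saturated chain carbon bound to an aromatic nitrogen, so methyl becomes ethyl.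

The closest guide is the step that placed the methyl on that aromatic nitrogen, a 7.2-fold higher number from compound 2 to compound 3 (0.86 log units; beyond the scatter). It suggests that adding to this nitrogen costs activity. The other measured step, a 3.0-fold lower number from compound 1 to compound 2 (0.48 log units; beyond the scatter), swaps hydroxy for fluoro on an aromatic carbon. That is a different change in a different place, and compound 3 and compound 4 both keep the hydroxy, so it offers little guidance here.

Among the compounds with values here, a single step is thin evidence, and no measured compound has a chain longer than methyl on that nitrogen. A further rise in this assay is therefore expected, but smaller than the earlier one and possibly no larger than the scatter. The estimated change is a 1.5-fold higher number from compound 3 to compound 4 (0.16 log units; within the scatter). For compound 4 the estimated value is 2500 nM, with an expected range from 1000 nM to 6500 nM.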

Compound 4, half-maximal inhibitory concentration: > 20000 nM
Compound 4: only a limit was reported; the forecaster's own chance of this, stated with the estimate: 10%; middle value at least 8.0-fold (0.90 log units) away from the limit.
By their numbers in this assay, from the lowest: compound 2; then compound 1; then compound 3. At a limit, above all of these: compound 4.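

In this assay, within the data shown here, compound 4 gives > 20000 nM, which is a limit and not a number, and it is the only such value in this set: the limit of > 20000 nM in this assay, at which 1 of the 4 values shown sits. Turning the methyl on the aromatic nitrogen into ethyl adds just one carbon, yet it gives an at least 11-fold higher number from compound 3 to compound 4 (1.06 log units; beyond the scatter), a larger change than the one that first placed the methyl there, a 7.2-fold higher number from compound 2 to compound 3 (0.86 log units; beyond the scatter). Among these compounds, measured against the compound with hydrogen on that nitrogen, the ethyl group gives an at least 83-fold higher number from compound 2 to compound 4 (1.92 log units; beyond the scatter), so the earlier compounds showed only that a methyl here costs activity, while this result shows that one further carbon on the same chain costs far more.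

On these data alone, the true size of both new steps stays open, since each rests on a limit and gives only a minimum, and nothing here shows whether the loss continues or levels off with a propyl or longer chain on this nitrogen. As far as these compounds go, it is also open whether a chain ending in an amine or a carboxylic acid at this position would behave like ethyl or would bring activity back towards that of compound 2.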